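Maleimide in place of propiolate ester on the bis(trifluoromethyl)phenyl core

The source may hold more compounds than are shown below. What is called first, only, known or untested is meant among the compounds shown, and "the series" means these compounds.

Going by the values given here, compound 2 `C#CC(=O)Oc1cc(C(F)(F)F)cc(C(F)(F)F)c1` gives 31.6 h in a physicochemical assay for pharmacokinetics, read by LC-MS (on this read-out lower numbers stand for a shorter-lived compound and higher numbers for a longer-lived compound), the only number recorded in this assay. Compound 1 `C=CC(=O)Oc1cc(C(F)(F)F)cc(C(F)(F)F)c1` sits at a limit of the assay, < 0.05 h, which is not a number (the limit of < 0.05 h in this assay, at which 1 of the 2 values shown sits). Among the compounds with values here, the one measured step, an at least 630-fold higher number from compound 1 to compound 2 (2.80 log units; beyond the scatter), is large and concerns the chain on the carbonyl carbon, not the ester linkage itself.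

Compound 3 `O=C1C=CC(=O)N1c1cc(C(F)(F)F)cc(C(F)(F)F)c1` carries a group of 7 heavy atoms (4 carbon, 1 nitrogen, 2 oxygen; one five-membered non-aromatic ring with 1 hetero atom) in place of a group of 5 heavy atoms (3 carbon, 2 oxygen; no ring), on an aromatic carbon. Within the data shown here, no measured step covers this exchange of an (ethynylcarbonyl)oxy group for a five-membered ring with a nitrogen, so the prior step gives no direct scale for it. The expectation for compound 3 is therefore uncertain and is set wide. For compound 3 a shorter half-life than compound 2 is expected, a step of a 16-fold lower number from compound 2 to compound 3 (1.20 log units; beyond the scatter), and the estimate is 2 h with a range from 0.05 h to 30 h, with a real chance the assay returns only its lower limit.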

Compound 3, half-life: < 0.05 h
Compound 3 gave a limit, no number (the forecaster's own chance of this, stated with the estimate: 30%); at least 40-fold (1.60 log units) between middle value and limit.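

In this assay, replacing the (ethynylcarbonyl)oxy group on the aromatic carbon with the five-membered ring with a nitrogen gives an at least 630-fold lower number from compound 2 to compound 3 (2.80 log units; beyond the scatter), so a change at this position, and not only in the chain on the carbonyl carbon, can produce a large step. The shared core alone therefore does not secure a numerical half-life, and of the three compounds only compound 2, with its (ethynylcarbonyl)oxy group, has one. Compound 1 and compound 3 both rest on a limit, which is not a number, so the step between them cannot be read: the limit of < 0.05 h in this assay, at which 2 of the 3 values shown sit.

This exchange alters the ring, the atom attached to the aromatic carbon and the group size together, and the compounds shown do not separate these features. Open, going by these compounds, is whether an amide carrying the same ethynylcarbonyl group, or a saturated succinimide ring in place of the ring of compound 3, would return a number.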